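A few compounds are considered here, and "the series" means these few. Any claim that something is new, unique, unknown or untested is made for them only; others in the source may bear on it.

In an ADME assay on MT4 cells (Homo sapiens) for cytotoxicity, read by MTT assay, with a stated time of 4 days (a higher number here means that more compound is tolerated, a lower number that less compound is tolerated), three compounds built around two closely related cores have been measured. Compound 1, with the structure `CCN(C)c1nc(Cc2c(F)cccc2F)cc(=O)[nH]1`, is one of them. In this assay compound 1 reaches only a limit of the measurement, > 89000 nM. Compound 2, with the structure `CCCN(C)c1nc(Cc2c(F)cccc2F)cc(=O)[nH]1`, differs from compound 1 by one change: methyl in place of hydrogen on a saturated chain carbon, two bonds along the chain from a nitrogen on an aromatic ring. In this assay compound 2 gives 85000 nM. The step is an at least 1.0-fold lower number from compound 1 to compound 2 (0.01 log units; that floor lies within the scatter), so the two numbers sit together, with the limit of > 89000 nM in this assay, at which 1 of the 3 values shown sits, marking where the first of them stops.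

Compound 3 has the structure `Cc1c(C(C)c2c(F)cccc2F)nc(N(C)C)[nH]c1=O`. The difference between the core of compound 3 and the core of compound 1 is not broken down here. In this assay compound 3 again reaches only a limit, > 17000 nM, which is the point named by the limit of > 17000 nM in this assay, at which 1 of the 3 values shown sits.

Compound 4, with the structure `CCc1c(C(C)c2c(F)cccc2F)nc(N(C)C)[nH]c1=O`, has not yet been measured. It differs from compound 3 by methyl in place of hydrogen on a saturated chain carbon bound to an aromatic carbon. This is the same kind of change as that from compound 1 to compound 2, though the place differs: there the methyl entered on a saturated chain carbon, two bonds along the chain from a nitrogen on an aromatic ring, whereas here it enters on a saturated chain carbon bound to an aromatic carbon. The earlier step stayed within the scatter, so a small step is expected here too, a step that the limit leaves unreadable from compound 3 to compound 4, resting on compound 3 with its limit > 17000 nM and on the step from compound 1 to compound 2 an at least 1.0-fold lower number from compound 1 to compound 2 (0.01 log units; that floor lies within the scatter). Compound 4 is therefore estimated at 20000 nM, most likely between 8000 nM and 60000 nM.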

Compound 4, half-maximal cytotoxic concentration: > 81000 nM
Compound 4: only a limit was reported (the forecaster's own chance of this, stated with the estimate: 65%); at least 4.0-fold (0.60 log units) between middle value and limit.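

In this assay, among the compounds shown here, compound 3 and compound 4 each reach only a limit of the measurement, so no step between them can be read. The compounds shown leave open how much of compound 3 or compound 4 is actually tolerated, and so whether methyl in place of hydrogen on a saturated chain carbon bound to an aromatic carbon shifts the number at all.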